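Clearance notes on two amide analogues and a pyridyl variant

A few compounds are considered here, and "the series" means these few. Any claim that something is new, unique, unknown or untested is made for them only; others in the source may bear on it.

Measured so far:
compound 1 `Cc1cccc(NC(=O)[C@H]2CN(C)C[C@@H]2c2ccc(/C=C/C(=O)Nc3ccccc3N)cc2)c1` — 74 mL/min/kg
compound 2 `CN1C[C@H](C(=O)Nc2ccc(F)c(F)c2)[C@@H](c2ccc(/C=C/C(=O)Nc3ccccc3N)cc2)C1` — 46 mL/min/kg

In an in vitro ADME assay on microsomes from liver (Mus musculus) for pharmacokinetics, read by LC-MS, with a stated time of 10 min, tested at 1 uM (on this read-out higher numbers stand for fast clearance and lower numbers for slow clearance), compound 2 gives 46 mL/min/kg; compound 1 gives 74 mL/min/kg. Among the compounds with values here, compound 2 holds the lowest of the two numbers, but the only step in the set, a 1.6-fold lower number from compound 1 to compound 2 (0.21 log units; within the scatter), sits within the scatter, so the two compounds are not separated.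

Compound 3 `CN1C[C@H](C(=O)Nc2ccccn2)[C@@H](c2ccc(/C=C/C(=O)Nc3ccccc3N)cc2)C1` carries the change (pyridin-2-yl in place of 3,4-difluorophenyl on an amide-type nitrogen). Within the data shown here, no measured step covers this change: the one step available swaps one carbon ring for another on the same amide-type nitrogen and moved the number only within the scatter. From the compounds shown here alone, an aromatic nitrogen entering the ring is untested here, so the expectation for compound 3 is a step of a 1.1-fold higher number from compound 2 to compound 3 (0.04 log units; within the scatter) in this assay, not beyond the scatter, with a wide range. Compound 3 is estimated at 50 mL/min/kg, between 25 mL/min/kg and 100 mL/min/kg.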

Compound 3, clearance: 40 mL/min/kg
For compound 3 the middle estimate is 1.3-fold (0.10 log units) above the measured one, and the stated range covers the measured number.
By their numbers in this assay, from the lowest: compounds 3, 2 and 1 (each within the scatter of the next).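

In this assay, pyridin-2-yl on the amide-type nitrogen brings a ring nitrogen and a hydrogen-bond acceptor into this place, and the clearance stays within the scatter of both carbon-only rings (a 1.2-fold lower number from compound 2 to compound 3 (0.06 log units; within the scatter); a 1.9-fold lower number from compound 1 to compound 3 (0.27 log units; within the scatter)). Across compounds 1, 2 and 3, this place therefore accepts 3-methylphenyl, 3,4-difluorophenyl and pyridin-2-yl without separating the numbers, so no trend can be drawn among these three aromatic rings. Nothing at hand bears on what lies behind these numbers.

Still open, from the compounds shown here alone, is whether a group of another kind on this nitrogen, such as a morpholine ring, a carboxylic acid or a longer alkyl chain, would move clearance beyond the scatter. The compounds shown also leave open how far changes elsewhere on the shared core would matter.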